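The source may hold more compounds than are shown below. What is called first, only, known or untested is meant among the compounds shown, and "the series" means these compounds.

Measured compounds:
compound 1, `O=C1/C(=C/c2ccc(F)cc2)Cc2ccccc21`, 89000 nM in a functional assay on L1210 cells (Mus musculus) for inhibition; a lower number here means a stronger inhibitor, a higher number a weaker inhibitor;
compound 2, `O=C1/C(=C/c2ccc(Cl)cc2)Cc2ccccc21`, 54100 nM in this assay ;
compound 3, `O=C1CCCCC/C1=C\c1cccc(F)c1`, 382000 nM in this assay .

Compounds 1 and 2 share one core and differ at a single point: chloro in place of fluoro on an aromatic carbon. This change gave a 1.6-fold lower number from compound 1 to compound 2 (0.22 log units; within the scatter), so the two numbers are not separated beyond the usual scatter. Compound 3 has a different core; the difference between the two cores is not broken down here. Among the three measured compounds, compound 3 gives the highest number, and its gap to both compound 1 and compound 2 lies beyond the scatter.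

Compound 4, `O=C1CCCCC/C1=C\c1cccc(Cl)c1`, has not yet been measured in this assay. It differs from compound 3 as follows: chloro in place of fluoro on an aromatic carbon. This is the same kind of change as that from compound 1 to compound 2, though the place differs: in the first pair the group sits para to a large group, in the second pair meta to a group of 9 heavy atoms. Since the earlier step was a 1.6-fold lower number from compound 1 to compound 2 (0.22 log units; within the scatter), a step of similar small size is expected here, a 1.4-fold lower number from compound 3 to compound 4 (0.15 log units; within the scatter), resting on that single pair alone. Compound 4 is therefore estimated at 270000 nM, with a range from 120000 nM to 600000 nM.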

Compound 4, half-maximal inhibitory concentration: 144000 nM
Compound 4: middle estimate off by 1.9-fold (0.27 log units), on the high side; measured number inside the range.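

Chloro in place of fluoro on an aromatic carbon gave a 2.7-fold lower number from compound 3 to compound 4 (0.42 log units; beyond the scatter) in this assay, a modest step on the core of compound 3. Set beside the same change on the core of compound 1, the two steps cannot be told apart: the same change on two cores in this assay, a 1.6-fold lower number (0.22 log units; within the scatter) from compound 1 to compound 2 and a 2.7-fold lower number (0.42 log units; beyond the scatter) from compound 3 to compound 4, 1.6-fold (0.21 log units) apart, within the scatter of two such steps. For the compounds shown here, the change therefore carries from one core to the other without a size difference that can be resolved, but this rests on only two pairs in which the place of the group also differs, so it does not separate the role of the core from that of the place, nor does it explain the step.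

The compounds shown leave open how a group other than the two halogens, such as a methoxy group, a nitrile or an amine, would read in this assay on either core. As far as these compounds go, it also remains open whether chloro and fluoro would compare in the same way if each core carried the group at the same place.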